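A few compounds are considered here, and "the series" means these few. Any claim that something is new, unique, unknown or untested is made for them only; others in the source may bear on it.

Compound 2 `COc1cc(Cl)cc(-c2nn(-c3cccc(NC(=O)Nc4ccc(Cl)c(Cl)c4)c3)cc2-c2ccncc2)c1` stands highest of the two numbers measured in a functional assay on OVCAR-3 cells (Homo sapiens) for inhibition, read by sulforhodamine B assay, with a stated time of 48 h, tested at 10 uM (on this read-out lower numbers stand for a stronger effect and higher numbers for a weaker effect at the one concentration tested), giving 4.11%, while compound 1 `COc1cc(Cl)cc(-c2nn(-c3cccc(NC(=O)Nc4ccc(Cl)c(C(F)(F)F)c4)c3)cc2-c2ccncc2)c1` gives -22.6%, a difference described by a number 26.7 percentage points higher from compound 1 to compound 2 (beyond the scatter). Compound 3 `COc1cc(Cl)cc(-c2nn(-c3cccc(NC(=O)c4cccc(C(F)(F)F)c4)c3)cc2-c2ccncc2)c1` differs from compound 2 by 3-(trifluoromethyl)phenyl in place of (3,4-dichlorophenyl)amino on a carbonyl carbon. For the measured compounds named here, no measured step covers this change; the one measured step swaps only a single group on the outer ring, so it offers little guidance here. In this assay compound 3 is expected to give a step of a number 10.9 percentage points higher from compound 2 to compound 3 (beyond the scatter), with wide uncertainty. The estimate for compound 3 is therefore 15%, between -15% and 45%.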

Compound 3, a percentage reported as activity, at one concentration (the size of the read-out at that concentration, not a potency): 52.3%
Compound 3: the middle estimate sits 37.3 percentage points below what was measured; measured number outside the range, above it.
By their numbers in this assay, from the lowest: compound 1; then compound 2; then compound 3.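

In this assay, putting 3-(trifluoromethyl)phenyl on the carbonyl carbon in place of the (3,4-dichlorophenyl)amino group weakens the effect, giving a number 48.2 percentage points higher from compound 2 to compound 3 (beyond the scatter). The same kind of change starting from the (4-chloro-3-(trifluoromethyl)phenyl)amino group gives a number 74.9 percentage points higher from compound 1 to compound 3 (beyond the scatter), so both steps that remove the amide-type nitrogen's neighbouring amino group point the same way and are large. No measurement shown explains this loss of effect.

As far as these compounds go, each change alters the amino nitrogen and the ring substituents at once, so it remains open which of the two matters. A (3-(trifluoromethyl)phenyl)amino group on the same carbonyl carbon would separate them.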